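This account rests on a few compounds, and the source may have more. Where it says the series, first, only, none or still open, it means among the compounds named here.

Measured compounds:
Compound 1 `Cc1cc(Nc2ccc(C(=O)/C=C/c3cccc(Br)n3)cc2)n2nc(SCc3ccccc3)nc2n1` — in a functional assay on MGC-803 cells (Homo sapiens) for inhibition, read by sulforhodamine B assay, with a stated time of 72 h, tested at 10 uM (a lower number here means less inhibition, a higher number more inhibition at the concentration tested (going by the name of the read-out)), compound 1 gives 90.2%.
Compound 2 `CCc1cc(Nc2ccc(C(=O)/C=C/c3cccc(Br)n3)cc2)n2nc(SCc3ccccc3)nc2n1` — in this assay compound 2 gives 63%.

Compound 1 stands highest of the two numbers, with compound 2 nearest to it; the step of a number 27.2 percentage points lower from compound 1 to compound 2 (beyond the scatter) lies beyond the scatter. That step, however, concerns a different part of the shared core: it is the methyl in place of hydrogen on a saturated chain carbon bound to an aromatic carbon.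

Compound 3 `Cc1cc(Nc2ccc(C(=O)/C=C/c3cccc(Br)n3)cc2)n2nc(SCc3ccc(Cl)cc3)nc2n1` has not yet been measured in this assay. It differs from compound 1 by chloro in place of hydrogen on an aromatic carbon. Going by the values given here, no measured step touches this part of the molecule, the benzyl group on the sulfur, so the one step known, from compound 1 to compound 2, does not bear on the change directly. With nothing to indicate otherwise, compound 3 is expected to stay close to compound 1, with a step of a number 5.2 percentage points lower from compound 1 to compound 3 (within the scatter) that is expected to lie within the scatter. Compound 3 is estimated to give 85%, with a range from 65% to 96%.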

Compound 3, a percentage reported as inhibition, at one concentration (the size of the read-out at that concentration, not a potency): 90.2%
Beside the measured number, compound 3's estimate is 5.2 percentage points below it; measured number inside the range.
By their numbers in this assay, from the lowest: compound 2; then compounds 1 and 3 (each within the scatter of the next).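

In this assay the benzylsulfanyl group on the shared core is now touched for the first time among these compounds, and the change to (4-chlorobenzyl)sulfanyl gives no change at the digits printed from compound 1 to compound 3 (within the scatter) and so leaves the read-out where it stood. This place on the phenyl ring therefore accepts one added chlorine atom without any visible cost in inhibition at the concentration tested. Going by these compounds alone, that differs from the only other step available, a number 27.2 percentage points lower from compound 1 to compound 2 (beyond the scatter), which lies at another part of the shared core and shows that a single added methyl there can move the number, though nothing in the data given accounts for this result or for that contrast.

As far as these compounds go, the read-out comes from one concentration, so any difference in potency between compound 1 and compound 3 stays open, as does whether a methoxy group, an amine or a carboxylic acid in the place of the chloro would hold the number as well. Also open, from the compounds shown here alone, is whether a longer chain in the place of the benzyl group on the sulfur would keep the inhibition seen with compound 1.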